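Remote aryl swap on a furanylmethyl amine side chain

A few compounds are considered here, and "the series" means these few. Any claim that something is new, unique, unknown or untested is made for them only; others in the source may bear on it.

Among the compounds with values here, compound 1, `c1ccc(CCc2ccc3c(NCCCNCc4ccco4)ccnc3c2)cc1`, is one of two compounds measured in a physicochemical assay for acid dissociation. In this assay compound 1 gives 9.47, the higher of the two numbers, and compound 2, `Clc1ccc(Oc2ccc3c(NCCCNCc4ccco4)ccnc3c2)cc1`, gives 9.28. Within the data shown here, the only measured step between them, a number 0.19 log units lower from compound 1 to compound 2 (within the scatter), falls within the scatter, so the two numbers cannot be told apart.

Compound 3, `FC(F)(F)c1cccc(Cc2ccc3c(NCCCNCc4ccco4)ccnc3c2)c1`, has not yet been measured in this assay. It differs from compound 1 in one place: 3-(trifluoromethyl)phenyl in place of benzyl on a saturated chain carbon bound to an aromatic carbon. The shared core and the furanylmethyl-bearing chain are unchanged.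

Among the measured compounds shown here, no measured step follows this exact change. For the measured compounds named here, the one step on record, from compound 1 to compound 2, replaces one aryl-bearing group with another and leaves the number within the scatter. On that basis the step from compound 1 to compound 3 is expected to be a number 0.07 log units lower from compound 1 to compound 3 (within the scatter), which is not beyond the scatter. Compound 3 is therefore estimated to give 9.4 in this assay, with a range from 9.05 to 9.75.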

Compound 3, acid dissociation constant: 9.47
The estimate for compound 3 lay 0.07 log units below the measured number; low and high end bracket the measured number.
By their numbers in this assay, from the lowest: compounds 2, 1 and 3 (each within the scatter of the next).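

In this assay, the exchange of benzyl for 3-(trifluoromethyl)phenyl on a saturated chain carbon bound to an aromatic carbon gives no change at the digits printed from compound 1 to compound 3 (within the scatter), so a change at this place, which adds three fluorine atoms, leaves the number where it was within the scatter. The earlier step, a number 0.19 log units lower from compound 1 to compound 2 (within the scatter), concerned a change on an aromatic carbon, so the three compounds now show two different changes in the aryl-bearing part of the molecule, neither of them with a step beyond the scatter. No measurement on hand bears on why the number stays put here.

What the compounds shown leave open is whether a more different group at this place, such as an amine or a carboxylic acid in place of the trifluoromethyl group, would give a step beyond the scatter. They also leave open how the number responds to a longer chain in place of the furanylmethyl-bearing chain, a part that all three compounds share unchanged.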